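Pyridin-3-yl for 2-chlorophenyl on the alkyne

The compounds below may be only part of what the source reports. "The series", "measured", "known", "first", "only" and "open" are said of these compounds alone.

Measured so far:
compound 1 `Cc1ncccc1C#Cc1cc(Cl)ccc1OCC(=O)O`, 143 nM
compound 2 `O=C(O)COc1ccc(Cl)cc1C#Cc1ccccc1Cl`, 28 nM

For the measured compounds named here, in an assay on CHO cells for displacement of a labelled ligand from prostaglandin D2 receptor 2 (Homo sapiens), read by scintillation counting (on this read-out lower numbers stand for stronger inhibition and higher numbers for weaker inhibition), compound 2 gives the lowest of the two numbers; the only neighbour is compound 1, and a 5.1-fold lower number from compound 1 to compound 2 (0.71 log units; beyond the scatter). Compound 3 `O=C(O)COc1ccc(Cl)cc1C#Cc1cccnc1` is the next step: pyridin-3-yl in place of 2-chlorophenyl on a triple-bonded carbon. Going by the values given here, the one measured step that bears on it is the exchange of an aromatic ring on the same triple-bonded carbon, from compound 1 to compound 2, which was modest and beyond the scatter. Running that exchange the other way, compound 3 is expected to show a higher number than compound 2, a 4.3-fold higher number from compound 2 to compound 3 (0.63 log units; beyond the scatter). Compound 3 is therefore estimated at 120 nM, in the range 40 nM to 400 nM.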

Compound 3, inhibition constant: 117 nM
Compound 3: middle estimate off by 1.0-fold (0.01 log units), on the high side; low and high end bracket the measured number.
By their numbers in this assay, from the lowest: compound 2; then compounds 3 and 1 (each within the scatter of the next).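

Putting pyridin-3-yl in place of 2-chlorophenyl on the triple-bonded carbon weakens inhibition (a 4.2-fold higher number from compound 2 to compound 3 (0.62 log units; beyond the scatter)), which leaves compound 2 clearly ahead of both pyridine-bearing compounds. Hydrogen in place of methyl on the aromatic carbon of the pyridine ring gives no readable change (a 1.2-fold lower number from compound 1 to compound 3 (0.09 log units; within the scatter)), so the methyl makes no measurable difference here. Nothing measured here accounts for either step.

The step to compound 3 removes the chlorine and brings in the ring nitrogen together, and the compounds shown do not separate the two. A plain phenyl or a 2-methoxyphenyl on the same triple-bonded carbon would bear on that question.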